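The compounds below may be only part of what the source reports. "The series", "measured", "known", "first", "only" and "open" are said of these compounds alone.

Of the compounds shown here, three with the same core have been measured in a functional assay (muscle tissue) with Cavia porcellus as the target (a lower number here means that less compound is needed, a higher number that more compound is needed for the effect), and they differ only in the substituted phenyl group on a saturated ring carbon. Compound 1 `COC(=O)C1=C(C)N=C(C)/C(=C(\O)OC)C1c1cc(Cl)cc(Cl)c1` gives 93.3 nM, and compound 2 `COC(=O)C1=C(C)N=C(C)/C(=C(\O)OC)C1c1ccccc1Cl` gives 2.19 nM. Compound 3 `COC(=O)C1=C(C)N=C(C)/C(=C(\O)OC)C1c1cccc(N)c1` gives 2000 nM, the highest number of the three. It sits well above both neighbours, with a 21-fold higher number from compound 1 to compound 3 (1.33 log units; beyond the scatter) and a 910-fold higher number from compound 2 to compound 3 (2.96 log units; beyond the scatter).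

Compound 4 `CCc1ccccc1C1C(C(=O)OC)=C(C)N=C(C)/C1=C(\O)OC` carries 2-ethylphenyl in place of 3-aminophenyl on a saturated ring carbon. Its nearest measured match is compound 2, whose 2-chlorophenyl is the closest group in name to 2-ethylphenyl. The most relevant evidence is therefore a 910-fold higher number from compound 2 to compound 3 (2.96 log units; beyond the scatter), read backwards, since it leaves the same 3-aminophenyl behind. The step of a 43-fold lower number from compound 1 to compound 2 (1.63 log units; beyond the scatter) also shows how much the number can fall when 2-chlorophenyl is present.

Going by the values given here, no measured compound carries an ethyl group, so the full size of the step from compound 2 cannot simply be carried over. In this assay, a large step to a lower number is expected, though somewhat smaller than that one. The expected change is a 130-fold lower number from compound 3 to compound 4 (2.12 log units; beyond the scatter). For compound 4 the estimate is 15 nM, with an expected range from 3 nM to 80 nM.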

Compound 4, half-maximal effective concentration: 6.46 nM
Compound 4: middle estimate off by 2.3-fold (0.37 log units), on the high side; the measured number falls inside the stated range.
By their numbers in this assay, from the lowest: compound 2; then compound 4; then compound 1; then compound 3.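

In this assay, the chlorine of compound 2 is not required for a low number at this position: replacing it with ethyl, a group of carbon only, gives just a modest step (a 2.9-fold higher number from compound 2 to compound 4 (0.47 log units; beyond the scatter)). The 2-ethylphenyl group also lies far below both the 3-aminophenyl group (a 310-fold lower number from compound 3 to compound 4 (2.49 log units; beyond the scatter)) and the 3,5-dichlorophenyl group (a 14-fold lower number from compound 1 to compound 4 (1.16 log units; beyond the scatter)), so among these four compounds, the 2-chlorophenyl and 2-ethylphenyl groups give the two lowest numbers, while the 3-aminophenyl and 3,5-dichlorophenyl groups give the higher ones. Nothing available explains why the number moves with these groups.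

The large step from the 3-aminophenyl group changes both the substituent and its place on the phenyl ring, so 2-aminophenyl and 3-ethylphenyl would be needed to tell those two changes apart. On these data alone, it also remains open how far this position tolerates size, which a smaller methyl or a longer propyl chain in place of the ethyl would begin to show.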